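The source may report more compounds than this note shows. Statements on the series, on what has been measured and on what is new or still open speak of the compounds shown alone.

Measured so far in an ADME assay on Raji cells (Homo sapiens) for cytotoxicity, read by luminescence, with a stated time of 72 h (a lower number here means that less compound is needed, a higher number that more compound is needed for the effect), are three compounds:
compound 1 `CCOC(=O)c1c(-c2cc(F)cc(OC)c2)[nH]c2cc(OC)ccc2c1=O` gives > 21500 nM as a limit
compound 2 `C=Cc1cccc(-c2[nH]c3cc(OC)ccc3c(=O)c2C(=O)OCC)c1` gives > 21500 nM as a limit
compound 3 `CCOC(=O)c1c(-c2cccc(C(C)=O)c2)[nH]c2cc(OC)ccc2c1=O` gives > 21500 nM as a limit

None of these three entries is a number. Compound 1 stands at the limit of > 21500 nM in this assay, at which 3 of the 3 values shown sit, and so offers a limit rather than a measured position.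

Compound 4 `CCOC(=O)c1c(-c2cc(OC)cc(OC)c2)[nH]c2cc(OC)ccc2c1=O` differs from compound 1 by methoxy in place of fluoro on an aromatic carbon and carries methoxy in place of fluoro on an aromatic carbon, meta to a large group and meta to a methoxy group.

Among the compounds with values here, three measured steps bear on this change, namely (a step that the two limits leave unreadable from compound 1 to compound 2), (a step that the two limits leave unreadable from compound 1 to compound 3) and (a step that the two limits leave unreadable from compound 2 to compound 3), and none of them has a readable size. With only the limit for compound 1 (> 21500 nM) as a starting point, no step beyond the scatter is expected in this assay and no direction can be argued. The expected step is a step that the limit leaves unreadable from compound 1 to compound 4 on this reading. Compound 4 is estimated at 25000 nM with a range from 12000 nM to 50000 nM and is expected most likely to return a limit again.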

Compound 4, half-maximal effective concentration: > 21500 nM
Compound 4: a limit, no number; the forecaster's own chance of this, stated with the estimate: 85%; the middle value is on the limit's open side.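

Within the data shown here, compound 4 returns a limit in this assay, as compound 1 does, so no step between the two can be read. The compounds shown leave open what half-maximal effective concentration any of them has, and whether methoxy in place of fluoro changes it at all.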